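Swapping one 4-cyanophenyl arm on the acetamido compound

A few compounds are considered here, and "the series" means these few. Any claim that something is new, unique, unknown or untested is made for them only; others in the source may bear on it.

For the measured compounds named here, in a functional assay on QGY-7703 cells (Homo sapiens) for cytotoxicity, read by MTT assay, with a stated time of 24 h (a lower number here means a stronger inhibitor, a higher number a weaker inhibitor), compound 1 `N#Cc1ccc(/C=C2\CN(S(=O)(=O)c3ccc(F)cc3)C/C(=C\c3ccc(C#N)cc3)C2=O)cc1` gives 11300 nM and compound 2 `CC(=O)Nc1ccc(S(=O)(=O)N2C/C(=C\c3ccc(C#N)cc3)C(=O)/C(=C/c3ccc(C#N)cc3)C2)cc1` gives 3320 nM, so compound 2 holds the lower of the two numbers so far. Compound 3 `CC(=O)Nc1ccc(S(=O)(=O)N2C/C(=C\c3ccc(C#N)cc3)C(=O)/C(=C/c3ccccc3F)C2)cc1` is the next entry. Its difference from compound 2 is 2-fluorophenyl in place of 4-cyanophenyl on a double-bonded chain carbon bound to a double-bonded ring carbon, with 2-fluorophenyl in place of 4-cyanophenyl on a double-bonded chain carbon bound to a double-bonded ring carbon.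

Going by the values given here, the only measured step is a 3.4-fold lower number from compound 1 to compound 2 (0.53 log units; beyond the scatter). It is modest and beyond the scatter, but it records acetamido in place of fluoro on an aromatic carbon, a change at a different place. Among the compounds with values here, no measured step covers the present swap, so neither size nor direction is established. The estimated change, a 1.1-fold lower number from compound 2 to compound 3 (0.04 log units; within the scatter), is therefore expected to stay within the scatter, with a wide margin either way. For compound 3 the estimated value is 3000 nM, with an expected range of 1000 nM to 9000 nM.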

Compound 3, half-maximal inhibitory concentration: 2050 nM
Compound 3: middle estimate off by 1.5-fold (0.17 log units), on the high side, and the stated range covers the measured number.
By their numbers in this assay, from the lowest: compounds 3 and 2 (each within the scatter of the next); then compound 1.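

In this assay, the change on a double-bonded chain carbon bound to a double-bonded ring carbon gives a 1.6-fold lower number from compound 2 to compound 3 (0.21 log units; within the scatter) and so does not separate 2-fluorophenyl from 4-cyanophenyl at this position. With the other 4-cyanophenyl arm and the acetamido group held constant, this arm can lose its nitrile without a step beyond the scatter, a point the earlier fluoro-to-acetamido step could not address. No accompanying measurement bears on this result.

As far as these compounds go, this single pair sets no pattern, and it remains open whether the second 4-cyanophenyl arm would accept the same swap. An arm carrying a carboxylic acid or a dimethylamino group in place of 4-cyanophenyl would test whether the numbers stay this close for groups unlike these two.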